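A Trifluoromethoxy Group Takes the Place of Phenyl

This account rests on a few compounds, and the source may have more. Where it says the series, first, only, none or still open, it means among the compounds named here.

Of the compounds shown here, three sharing one core have been measured in an assay on isolated protein for inhibition of tyrosine-protein kinase receptor UFO (Homo sapiens), read by FRET and Z'-LYTE, with a stated time of 1.5 h; on this read-out lower numbers stand for stronger inhibition and higher numbers for weaker inhibition. Compound 1 `CCCc1ccc2c(c1)c(=O)c(C(=O)Nc1ccc(Oc3ncnc4[nH]cc(-c5ccccc5)c34)c(F)c1)c(C)n2C` carries a propyl group and gives 61 nM. Compound 2 `Cc1c(C(=O)Nc2ccc(Oc3ncnc4[nH]cc(-c5ccccc5)c34)c(F)c2)c(=O)c2cc(C(C)(C)C)ccc2n1C` carries tert-butyl at the same position and gives 42 nM, so that a 1.5-fold lower number from compound 1 to compound 2 (0.16 log units; within the scatter). Compound 3 `Cc1c(C(=O)Nc2ccc(Oc3ncnc4[nH]cc(-c5ccccc5)c34)c(F)c2)c(=O)c2cc(-c3ccccc3)ccc2n1C` carries phenyl there; for compound 3 this assay reports only a limit, > 10000 nM, and compound 3 therefore sits at the limit of > 10000 nM in this assay, at which 1 of the 3 values shown sits, rather than at a number. The steps into compound 3 are both large: an at least 160-fold higher number from compound 1 to compound 3 (2.21 log units; beyond the scatter) and an at least 230-fold higher number from compound 2 to compound 3 (2.37 log units; beyond the scatter).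

Compound 4 `Cc1c(C(=O)Nc2ccc(Oc3ncnc4[nH]cc(-c5ccccc5)c34)c(F)c2)c(=O)c2cc(OC(F)(F)F)ccc2n1C` differs from compound 3 in that (trifluoromethoxy in place of phenyl on an aromatic carbon). The two steps that bear on this change are the ones just named, each beyond the scatter and each in the losing direction, and compound 4 reverses the phenyl step without restoring either alkyl group. Going by the values given here, a large step back toward the numbers of compound 1 and compound 2 is therefore expected, although the data hold no measured trifluoromethoxy analogue. Compound 4 is estimated to give 150 nM in this assay, between 40 nM and 1500 nM, which means an expected step of an at least 66-fold lower number from compound 3 to compound 4 (1.82 log units; beyond the scatter).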

Compound 4, half-maximal inhibitory concentration: 74 nM
For compound 4 the middle estimate is 2.0-fold (0.31 log units) above the measured one, within the range that was stated.
By their numbers in this assay, from the lowest: compounds 2, 1 and 4 (each within the scatter of the next). At a limit, above all of these: compound 3.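

In this assay the step of an at least 130-fold lower number from compound 3 to compound 4 (2.13 log units; beyond the scatter) shows that this position does not depend on an alkyl group, since trifluoromethoxy, which holds oxygen and fluorine, also escapes the result seen with phenyl. The new group cannot be told apart from either alkyl group, with a 1.2-fold higher number from compound 1 to compound 4 (0.08 log units; within the scatter) and a 1.8-fold higher number from compound 2 to compound 4 (0.25 log units; within the scatter), so the position accepts three groups of different atoms on the same level. Among the four groups, only phenyl gives a limit rather than a number, as compound 3 stands at it: the limit of > 10000 nM in this assay, at which 1 of the 4 values shown sits.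

Phenyl is the only group here that brings a ring, so it stays open whether a cyclohexyl or pyridyl group would meet the same fate. From the compounds shown here alone, it is equally open whether an amine or a carboxylic acid at this position would be accepted like the three groups that give numbers.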